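A few compounds are considered here, and "the series" means these few. Any claim that something is new, unique, unknown or untested is made for them only; others in the source may bear on it.

Compound 1 `CNS(=O)(=O)c1ccc2c(c1)C(n1ccccc1=O)=CC(C)(C)O2` gives 138 nM in a functional assay with Rattus norvegicus as the target; on this read-out lower numbers stand for an effect already at smaller amounts and higher numbers for an effect only at larger amounts of compound. Compound 2 `COc1ccc(NS(=O)(=O)c2ccc3c(c2)C(n2ccccc2=O)=CC(C)(C)O3)cc1` gives 490 nM. Compound 3 `CC1(C)C=C(n2ccccc2=O)c2cc(S(=O)(=O)Nc3ccc([N+](=O)[O-])cc3)ccc2O1` gives 10200 nM.

Among these three, compound 1 has the lowest number in this assay. Its nearest neighbour is compound 2, reached by a 3.6-fold higher number from compound 1 to compound 2 (0.55 log units; beyond the scatter); its furthest is compound 3, reached by a 74-fold higher number from compound 1 to compound 3 (1.87 log units; beyond the scatter). The remaining step, a 21-fold higher number from compound 2 to compound 3 (1.32 log units; beyond the scatter), changes a group on an aromatic carbon rather than the sulfonamide nitrogen itself.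

Compound 4 `CN(c1ccccc1)S(=O)(=O)c1ccc2c(c1)C(n1ccccc1=O)=CC(C)(C)O2` has not been measured. It differs from compound 1 by phenyl in place of hydrogen on a sulfonamide nitrogen; read one bond further out, methylamino becomes methyl(phenyl)amino, so the methyl stays and a phenyl is added.

Going by the values given here, the steps that bear on this are a 3.6-fold higher number from compound 1 to compound 2 (0.55 log units; beyond the scatter) and a 74-fold higher number from compound 1 to compound 3 (1.87 log units; beyond the scatter): both placed a six-membered aromatic ring on the same sulfonamide nitrogen and both raised the number, modestly for the methoxy-bearing ring and strongly for the nitro-bearing one. Compound 4 carries a plain phenyl while keeping the methyl, so the expectation is a rise in this assay of modest size, closer to the first of those steps than the second, giving a 2.9-fold higher number from compound 1 to compound 4 (0.46 log units; beyond the scatter) as the estimated step. For compound 4 the estimate is 400 nM, expected to lie between 130 nM and 1300 nM.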

Compound 4, half-maximal effective concentration: 9.77 nM
Estimate against measurement, compound 4: 41-fold (1.61 log units) above, and the stated range ends above it.
By their numbers in this assay, from the lowest: compound 4; then compound 1; then compound 2; then compound 3.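

In this assay, a phenyl on the sulfonamide nitrogen with the methyl kept moves the number down, not up (a 14-fold lower number from compound 1 to compound 4 (1.15 log units; beyond the scatter)), so among these compounds an aromatic ring on this nitrogen does not always raise it. Compound 4 is also the only one of the four with no hydrogen left on that nitrogen, and it sits far below the two compounds that carry a substituted phenyl and keep that hydrogen (a 50-fold lower number from compound 2 to compound 4 (1.70 log units; beyond the scatter); a 1000-fold lower number from compound 3 to compound 4 (3.02 log units; beyond the scatter)), although those two steps change the methyl and the substituent on the ring together and so cannot be assigned to either one alone. No measurement shown here explains this reversal.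

The compounds shown do not separate the contribution of the phenyl from that of losing the nitrogen's hydrogen, since a plain phenylamino group, which would keep the hydrogen, and a dimethylamino group, which would lose it without adding a ring, are both absent from this set. As far as these compounds go, it also remains open whether the low number survives an ethyl in place of the methyl, or a methoxy or nitro group on the phenyl of compound 4.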